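A Hydroxy Analogue Estimated from Three Measured Compounds

A few compounds are considered here, and "the series" means these few. Any claim that something is new, unique, unknown or untested is made for them only; others in the source may bear on it.

Compound 1 `O=C(CSc1nnc(-c2ccncc2)o1)N/N=C/c1ccccc1`: 22100 nM
Compound 2 `O=C(CSc1nnc(-c2ccncc2)o1)N/N=C/c1ccc(Br)cc1`: 24500 nM
Compound 3 `O=C(CSc1nnc(-c2ccncc2)o1)N/N=C/c1ccc([N+](=O)[O-])cc1`: 31500 nM

All three compounds were tested in a functional assay on BGC-823 cells (Homo sapiens) for cytotoxicity, read by MTT assay, with a stated time of 48 h; a lower number here means a stronger inhibitor, a higher number a weaker inhibitor. Compound 3 shows the highest of the three numbers, but its gap to compound 2 and its gap to compound 1 both lie within the scatter, so the three compounds cannot be placed in any order of strength. Compound 4 `O=C(CSc1nnc(-c2ccncc2)o1)N/N=C/c1ccc(O)cc1` has not yet been measured; it differs from compound 3 by hydroxy in place of nitro on an aromatic carbon. For the measured compounds named here, no measured pair contains a hydroxy group, so the only guides are the earlier changes at the same carbon: a 1.1-fold higher number from compound 1 to compound 2 (0.04 log units; within the scatter), a 1.4-fold higher number from compound 1 to compound 3 (0.15 log units; within the scatter) and a 1.3-fold higher number from compound 2 to compound 3 (0.11 log units; within the scatter), each within the scatter. Because a 1.4-fold higher number from compound 1 to compound 3 (0.15 log units; within the scatter) and a 1.3-fold higher number from compound 2 to compound 3 (0.11 log units; within the scatter) both stayed within the scatter, the step in this assay is expected to be a 1.2-fold lower number from compound 3 to compound 4 (0.08 log units; within the scatter), with no movement beyond the scatter in either direction. Compound 4 is therefore estimated at 26000 nM, with a range from 12000 nM to 55000 nM.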

Compound 4, half-maximal inhibitory concentration: 7940 nM
Beside the measured number, compound 4's estimate is 3.3-fold (0.52 log units) above it, and the stated range ends above it.
By their numbers in this assay, from the lowest: compound 4; then compounds 1, 2 and 3 (each within the scatter of the next).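

In (this assay), the aromatic carbon para to a large group can shift the number beyond the scatter, something hydrogen, bromo and nitro at that carbon did not do among themselves. Hydroxy in that place stands apart from all three others, with (a 4.0-fold lower number from compound 3 to compound 4 (0.60 log units; beyond the scatter)), (a 3.1-fold lower number from compound 2 to compound 4 (0.49 log units; beyond the scatter)) and (a 2.8-fold lower number from compound 1 to compound 4 (0.44 log units; beyond the scatter)), so compound 4 is stronger than each of the other compounds and no compound shown goes against this. Nothing measured here gives a reason for this separation.

The compounds shown leave open whether a methoxy group, an amine or a carboxylic acid on this carbon would fall with hydroxy or stay with hydrogen, bromo and nitro. They also leave open whether hydroxy on another carbon of the same ring would give a similar step.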